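Methoxy Gives Way to Chloro on the Pendant Aryl Ring

The source may hold more compounds than are shown below. What is called first, only, known or untested is meant among the compounds shown, and "the series" means these compounds.

Of the compounds shown here, three sharing one core have been measured in a functional assay on HCT-116 cells (Homo sapiens) for cytotoxicity, read by MTT assay, with a stated time of 72 h; on this read-out lower numbers stand for stronger inhibition and higher numbers for weaker inhibition. Compound 3 `COc1ccc(-c2cc(/N=C3\SCC(=O)N3c3cccc(OC)c3)cs2)cc1` gives 2700 nM, the lowest of the two numbers recorded. Compound 2 `COc1cccc(N2C(=O)CS/C2=N\c2csc(-c3ccc(C)cc3)c2)c1` gives 41000 nM. Between them lies the only measured step, a 15-fold lower number from compound 2 to compound 3 (1.18 log units; beyond the scatter). Compound 1 `O=C1CS/C(=N\c2csc(-c3ccc(Cl)cc3)c2)N1` gives > 50000 nM, which is a limit of this assay and not a number; it is the limit of > 50000 nM in this assay, at which 1 of the 3 values shown sits. Going by the values given here, compound 1 lacks the aryl group on the ring nitrogen that compounds 2 and 3 carry, so no step connects it to either.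

Compound 4 `COc1cccc(N2C(=O)CS/C2=N\c2csc(-c3ccc(Cl)cc3)c2)c1` is the next member. It differs from compound 3 by chloro in place of methoxy on an aromatic carbon. Among the compounds with values here, the one measured step that touches this position, a 15-fold lower number from compound 2 to compound 3 (1.18 log units; beyond the scatter), shows that the group on this carbon can move the read-out strongly, yet it involved a methyl rather than a chloro, so it fixes no direction for the present change. Compound 1 also carries a chloro on that ring, but it is not a matched pair with compound 4. Compound 4 is therefore expected to land between the numbers of compounds 2 and 3. The estimate for compound 4 is 10000 nM, within a range from 2500 nM to 45000 nM. This estimate means an expected step of a 3.7-fold higher number from compound 3 to compound 4 (0.57 log units; beyond the scatter).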

Compound 4, half-maximal inhibitory concentration: > 50000 nM
Compound 4: a limit, no number; the forecaster's own chance of this, stated with the estimate: 15%; at least 5.0-fold (0.69 log units) between middle value and limit.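

Changing 4-methoxyphenyl to 4-chlorophenyl in this assay gives an at least 18-fold higher number from compound 3 to compound 4 (1.26 log units; beyond the scatter), so a group with a lower number on this aromatic carbon does not keep it when chloro enters, and the sensitivity seen earlier now has a second, opposite example. Against methyl, the change gives an at least 1.2-fold higher number from compound 2 to compound 4 (0.08 log units; that floor lies within the scatter), so chloro and methyl cannot be put in order, and among the three groups on this carbon only methoxy stands apart, with compound 3 holding the lowest number. The step between compound 1 and compound 4 cannot be read, as both values are limits and not numbers: the limit of > 50000 nM in this assay, at which 2 of the 4 values shown sit.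

From the compounds shown here alone, whether the lower number belongs to methoxy alone, or would also appear with an ethoxy, a hydroxy or a dimethylamino group on this carbon, stays open. It is also open whether the order among these groups would hold if the 3-methoxyphenyl on the ring nitrogen gave way to another aryl group, such as an unsubstituted phenyl.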